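Oral Exposure in Dogs: From Compound 2 to Compound 4

This account rests on a few compounds, and the source may have more. Where it says the series, first, only, none or still open, it means among the compounds named here.

Of the compounds shown here, three that share one core have been measured in an in vivo ADME assay on the whole organism (plasma) for pharmacokinetics, with Canis familiaris (Canis lupus familiaris) as the target, at a dose of 1 mg/kg by the oral route; on this read-out higher numbers stand for higher exposure at the dose given and lower numbers for lower exposure. Compound 1 `Cc1ccc(NS(=O)(=O)Cc2ccc(Br)cc2)c(=O)n1CC(=O)NCc1ccc2c(N)noc2c1` gives 2710 nM. Compound 2 `Cc1cnc(NCC2(c3ccccc3)CCC2)c(=O)n1CC(=O)NCc1ccc2c(N)noc2c1` gives 1310 nM. Compound 3 `Cc1cnc(NCC2(c3ccc(F)cc3)CC2)c(=O)n1CC(=O)NCc1ccc2[nH]nc(N)c2c1` gives 1850 nM. Among these three, compound 2 has the smallest number; its gap to compound 3 lies within the usual scatter of such measurements, so those two cannot be told apart, while its gap to compound 1 lies beyond it.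

Compound 4 `Cc1cnc(NCC2(c3ccccn3)CC2)c(=O)n1CC(=O)NCc1ccc2c(N)noc2c1` is not yet measured. It differs from compound 2 in one place: 1-(pyridin-2-yl)cyclopropyl in place of 1-phenylcyclobutyl on a saturated chain carbon bound to a nitrogen on an aromatic ring. Among the measured compounds shown here, no measured pair shows this change, so its effect is unknown. For compound 4 the estimated step of a 1.1-fold higher number from compound 2 to compound 4 (0.06 log units; within the scatter) in this assay is expected to stay small, in no clear direction, and within the scatter. In this assay compound 4 is expected to give about 1500 nM, most likely between 500 nM and 4500 nM.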

Compound 4, maximal plasma concentration in the Canis familiaris assay: 1680 nM
Estimate against measurement, compound 4: 1.1-fold (0.05 log units) below; the measured number falls inside the stated range.
By their numbers in the Canis familiaris assay, from the lowest: compounds 2, 4, 3 and 1 (each within the scatter of the next, the first and the last beyond it).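

In the Canis familiaris assay, compound 2 gives 1310 nM and compound 4 gives 1680 nM, and putting 1-(pyridin-2-yl)cyclopropyl in place of 1-phenylcyclobutyl gives a 1.3-fold higher number from compound 2 to compound 4 (0.11 log units; within the scatter), so this position accepts a smaller carbon ring and a hydrogen-bond acceptor in the aromatic ring with no readable shift in this read-out. In a physicochemical assay for acid dissociation, compound 2 gives 8.6 and compound 4 gives 8.6, and the same swap gives no change at the digits printed from compound 2 to compound 4 (within the scatter), so the acid dissociation constant also stays level. Nothing shown explains why the two groups read alike.

The swap alters the carbon ring and the aromatic ring together, so the compounds shown cannot tell whether each part has little effect or whether the two parts offset one another. Going by these compounds, a 1-phenylcyclopropyl group would separate these parts on this core, and how a group carrying a carboxylic acid at this place would read remains open.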